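Aryl-amide variation on the thiadiazole acid series

The compounds below may be only part of what the source reports. "The series", "measured", "known", "first", "only" and "open" are said of these compounds alone.

Measured compounds:
compound 1 `Cc1cccc(-c2cccc(NC(=O)c3nnc(CCC(=O)O)s3)c2)c1`: 760 nM
compound 2 `O=C(O)CCc1nnc(C(=O)Nc2cccc(-c3ccco3)c2)s1`: 1640 nM
compound 3 `Cc1cccc(NC(=O)c2nnc(COc3ccc(CCC(=O)O)cc3)s2)c1`: 1770 nM

In a functional assay on CHO cells for agonist activity at Free fatty acid receptor 1 (Homo sapiens), read by calcium flux (a lower number here means that less compound is needed, a higher number that more compound is needed for the effect), compound 3 gives the highest of the three numbers. Against compound 2 the gap is within the scatter, so no order between the two can be read; against compound 1 the gap is beyond the scatter, compound 1 needing less compound.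

Compound 4 `O=C(O)CCc1ccc(OCc2nnc(C(=O)Nc3ccc(F)c(F)c3)s2)cc1` is the next step. The change from compound 3 is 3,4-difluorophenyl in place of 3-methylphenyl on an amide-type nitrogen. For the measured compounds named here, only one measured step exists in the set, a 2.2-fold higher number from compound 1 to compound 2 (0.33 log units; beyond the scatter), and it concerns a different group at a different place, an aryl group on an aromatic carbon, not the amide-type nitrogen. Going by the values given here, no measured pair exchanges the aryl on the amide-type nitrogen, so the step to compound 4 has no direct precedent. On that basis the expectation is a step in this assay of no more than modest size, with no direction to be derived from the data; the estimate for compound 4 is 1500 nM, with a range from 600 nM to 4000 nM, meaning an expected step of a 1.2-fold lower number from compound 3 to compound 4 (0.07 log units; within the scatter).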

Compound 4, half-maximal effective concentration: 580 nM
Compound 4: middle estimate off by 2.6-fold (0.41 log units), on the high side, and the stated range ends above it.
By their numbers in this assay, from the lowest: compounds 4 and 1 (each within the scatter of the next); then compounds 2 and 3 (each within the scatter of the next).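

In this assay the aryl group on the amide-type nitrogen now has a measured effect: 3,4-difluorophenyl in place of 3-methylphenyl gives a 3.1-fold lower number from compound 3 to compound 4 (0.48 log units; beyond the scatter) in this first exchange at that place, whereas the earlier step concerned an aryl group on an aromatic carbon. Neither group carries a hydrogen-bond donor, a hydrogen-bond acceptor or a net charge, so the step appears with those counts unchanged. No measurement shown here bears on why the number falls.

From the compounds shown here alone, it remains open whether a single fluorine, as in 3-fluorophenyl or 4-fluorophenyl, accounts for the step or both fluorines are required. Also open, going by these compounds, is how larger or nitrogen-containing aryl groups, such as 3,4-dichlorophenyl or pyridyl, would read on the same amide-type nitrogen.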